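Swapping One Methoxy Group for Hydrogen

This account rests on a few compounds, and the source may have more. Where it says the series, first, only, none or still open, it means among the compounds named here.

Going by the values given here, only two compounds have been measured so far in a functional assay on HeLa cells (Homo sapiens) for cytotoxicity, read by MTT assay, with a stated time of 48 h; a lower number here means a stronger inhibitor, a higher number a weaker inhibitor. There, compound 1 `COc1cc(/C=C/c2ccccc2)c(-c2ccccc2)c(OC)c1OC` gives 89000 nM, while compound 2 `C=C(c1ccc(OC)cc1)c1cc(OC)c(OC)c(OC)c1-c1ccccc1` gives 11000 nM. Compound 2 therefore holds the lower of the two numbers, and the gap between them lies beyond the usual scatter of repeat measurements.

Compound 3 `C=C(c1ccccc1)c1cc(OC)c(OC)c(OC)c1-c1ccccc1` differs from compound 2 in one place, with hydrogen in place of methoxy on an aromatic carbon, para to a large group, so that 4-methoxyphenyl becomes phenyl (hydrogen in place of methoxy on an aromatic carbon). Among the compounds with values here, no measured pair shows this change on its own, so the expectation is loose. It rests on compound 2 at 11000 nM and compound 1 at 89000 nM, and a number between these two seems most likely. A modest loss of strength is expected, an estimated 2.3-fold higher number from compound 2 to compound 3 (0.36 log units; beyond the scatter). For compound 3 the estimated value is 25000 nM, with an expected range of 9000 nM to 70000 nM.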

Compound 3, half-maximal inhibitory concentration: 42000 nM
Compound 3: the middle estimate sits 1.7-fold (0.23 log units) below what was measured; low and high end bracket the measured number.
By their numbers in this assay, from the lowest: compound 2; then compound 3; then compound 1.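

In this assay, going by these compounds alone, going from 4-methoxyphenyl to phenyl gives a 3.8-fold higher number from compound 2 to compound 3 (0.58 log units; beyond the scatter) and shows for the first time that this position, on an aromatic carbon para to a large group, affects the result, with methoxy giving the lower number of the two groups compared. The other change, 1-phenylethenyl in place of 2-phenylethenyl, gives a 2.1-fold lower number from compound 1 to compound 3 (0.33 log units; beyond the scatter) and shows that the form of this linking group also counts, even without the methoxy. Nothing available explains why either change shifts the number.

From the compounds shown here alone, it remains open whether a different group in the same place, such as an amine, a fluorine atom or a longer ether such as ethoxy, would give a lower or a higher number. It is also unknown whether adding methoxy to compound 1 would have a similar effect.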